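A few compounds are considered here, and "the series" means these few. Any claim that something is new, unique, unknown or untested is made for them only; others in the source may bear on it.

Compound 1 `OB(O)c1ccc2ncnc(Nc3ccc(F)c(Cl)c3)c2c1` gives > 1000 nM in an assay on isolated protein for inhibition of vascular endothelial growth factor receptor 1 (Homo sapiens), read by ELISA, with a stated time of 20 min (a lower number here means a stronger inhibitor, a higher number a weaker inhibitor), a limit of the assay.
Compound 2 `COc1cc2ncnc(Nc3ccc(F)c(Cl)c3)c2cc1B(O)O` gives > 1000 nM in this assay, also a limit.
Compound 3 `COCCOc1cc2ncnc(Nc3cccc(B(O)O)c3)c2cc1OCCOC` gives > 1000 nM in this assay, again a limit.

Compound 3 thus stands at the limit, as every shown value does (the limit of > 1000 nM in this assay, at which 3 of the 3 values shown sit). Among the compounds with values here, the single measured step, a step that the two limits leave unreadable from compound 1 to compound 2, is left unreadable by the two limits it joins, so no size is known for any change. Compound 4 `COCCOc1cc2ncnc(Nc3cccc(B(O)O)c3)c2cc1OC` differs from compound 3 by hydrogen in place of methoxymethyl on a saturated chain carbon bound to an oxygen on an aromatic ring. Within the data shown here, no measured step bears on this change. With nothing beyond limits to lean on, the expectation is that compound 4 stays at the limit of this assay, and the expected step that the limit leaves unreadable from compound 3 to compound 4 carries no measured support. Compound 4 is estimated at 3000 nM, within 800 nM to 20000 nM.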

Compound 4, half-maximal inhibitory concentration: > 1000 nM
Compound 4 gave a limit, no number; the forecaster's own chance of this, stated with the estimate: 80%; the middle value does not contradict the limit.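

No step can be read from compound 3 to compound 4, since both values are limits in this assay, as is every value shown: the limit of > 1000 nM in this assay, at which 4 of the 4 values shown sit.

The compounds shown leave open whether replacing 2-methoxyethoxy with methoxy changes inhibition at all, and in which direction.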